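A Triflate Replaces Hydrogen on the Shared Core

The compounds below may be only part of what the source reports. "The series", "measured", "known", "first", "only" and "open" are said of these compounds alone.

compound 1 `Cc1[nH]c2ccc(Br)cc2c1C1=CCNCC1`: 75 nM
compound 2 `Cc1[nH]c2ccccc2c1C1=CCNCC1`: 890 nM

In an assay on isolated protein for displacement of a labelled ligand from 5-hydroxytryptamine receptor 1B (Rattus norvegicus) (a lower number here means a stronger inhibitor, a higher number a weaker inhibitor), compound 2 gives the higher of the two numbers, compound 1 the lower. Compound 3 `Cc1[nH]c2ccc(OS(=O)(=O)C(F)(F)F)cc2c1C1=CCNCC1` differs from compound 2 by ((trifluoromethyl)sulfonyl)oxy in place of hydrogen on an aromatic carbon, at the aromatic carbon that carries bromo in compound 1. Among the compounds with values here, the one measured step that bears on this is a 12-fold higher number from compound 1 to compound 2 (1.07 log units; beyond the scatter), a large effect of a substituent at that carbon. As far as these compounds go, a group entering there is therefore expected to lower the number again, a 5.9-fold lower number from compound 2 to compound 3 (0.77 log units; beyond the scatter), though whether the new group matches bromo is untested. Compound 3 is estimated at 150 nM, within 40 nM to 600 nM.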

Compound 3, half-maximal inhibitory concentration: 29 nM
The estimate for compound 3 lay 5.2-fold (0.71 log units) above the measured number; measured number below the stated range.
By their numbers in this assay, from the lowest: compound 3; then compound 1; then compound 2.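

In this assay, ((trifluoromethyl)sulfonyl)oxy at this aromatic carbon gives a 31-fold lower number from compound 2 to compound 3 (1.49 log units; beyond the scatter), so this position accepts a group of 8 heavy atoms with no loss, and the number falls further than bromo took it. Replacing bromo gives a 2.6-fold lower number from compound 1 to compound 3 (0.41 log units; beyond the scatter), showing that the lower number at this carbon is not confined to bromo. As far as these compounds go, whether a methoxy group or an amine at the same carbon would also lower the number remains open, as does the response of other positions on the shared core. Nothing available here accounts for either step.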